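The source may report more compounds than this note shows. Statements on the series, on what has been measured and on what is new or still open speak of the compounds shown alone.

Compound 2 `COc1cc2c(Oc3ccc(NC(=O)c4nn(-c5ccccc5C(F)(F)F)c(=O)cc4C)cc3F)ccnc2cc1OCCCN1CCCC1` holds the lowest of the two numbers measured in a functional assay on HT-29 cells (Homo sapiens) for inhibition, read by MTT assay, with a stated time of 72 h (a higher number here means a weaker inhibitor, a lower number a stronger inhibitor), where compound 2 gives 140 nM. For the measured compounds named here, its only neighbour is compound 1 `COc1cc2c(Oc3ccc(NC(=O)c4nn(-c5ccccc5C)c(=O)cc4C)cc3F)ccnc2cc1OCCCN1CCCC1`, which in this assay gives 1400 nM; the two are separated by a 10-fold lower number from compound 1 to compound 2 (1.00 log units; beyond the scatter). Compound 3 `COc1cc2c(Oc3ccc(NC(=O)c4nn(-c5ccccc5OC(F)(F)F)c(=O)cc4C)cc3F)ccnc2cc1OCCCN1CCCC1` is the compound not yet measured. It differs from compound 2 by trifluoromethoxy in place of trifluoromethyl on an aromatic carbon. Going by the values given here, no measured step covers this exchange. Among the compounds with values here, the single measured step, a 10-fold lower number from compound 1 to compound 2 (1.00 log units; beyond the scatter), bears on it only in that methyl at the same place had already been exchanged for trifluoromethyl, which lowered the number. Trifluoromethoxy resembles trifluoromethyl in its make-up, so compound 3 is expected to stay near compound 2, and a 1.4-fold higher number from compound 2 to compound 3 (0.15 log units; within the scatter) is expected to remain within the scatter. The estimate for compound 3 in this assay is therefore 200 nM, with a range from 70 nM to 600 nM.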

Compound 3, half-maximal inhibitory concentration: 180 nM
For compound 3 the middle estimate is 1.1-fold (0.05 log units) above the measured one; measured number inside the range.
By their numbers in this assay, from the lowest: compounds 2 and 3 (each within the scatter of the next); then compound 1.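

In this assay, trifluoromethoxy in place of trifluoromethyl, on an aromatic carbon ortho to a large group, gives a 1.3-fold higher number from compound 2 to compound 3 (0.11 log units; within the scatter), so the two groups cannot be told apart at this place. Trifluoromethoxy in place of methyl gives a 7.8-fold lower number from compound 1 to compound 3 (0.89 log units; beyond the scatter), which shows that the lower number against methyl is not tied to trifluoromethyl alone, since two fluorinated groups now share it. Nothing available explains why these two groups read alike here.

The compounds shown leave open what a plain methoxy, a chlorine atom or an amine would give at this place, and so whether the fluorine atoms matter at all. They also leave open whether a carboxylic acid or a longer chain here would keep the number near that of compound 2.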